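Furan-2-yl in place of phenyl: compound 4 expected

A few compounds are considered here, and "the series" means these few. Any claim that something is new, unique, unknown or untested is made for them only; others in the source may bear on it.

Compound 1 `O=C(O)c1ccc(CN2C(=O)S/C(=C\c3ccccc3)C2=O)cc1` in a functional assay on HT-29 cells (Homo sapiens) for cytotoxicity, read by MTT assay, with a stated time of 24 h (a lower number here means a stronger inhibitor, a higher number a weaker inhibitor), gives 88000 nM. Compound 2 `O=C(O)c1ccc(CN2C(=O)S/C(=C\c3cccs3)C2=O)cc1` gives 88000 nM in this assay, and compound 3 `Cc1ccc(/C=C2\SC(=O)N(Cc3ccc(C(=O)O)cc3)C2=O)cc1` gives 72000 nM. Compound 1 stands level with compound 2 at the digits shown, the two together the highest of the three numbers; its nearest is compound 2, with no change at the digits printed from compound 1 to compound 2 (within the scatter), its furthest compound 3, with a 1.2-fold lower number from compound 1 to compound 3 (0.09 log units; within the scatter).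

Compound 4 `O=C(O)c1ccc(CN2C(=O)S/C(=C\c3ccco3)C2=O)cc1` is not yet measured. Relative to compound 1 the change is furan-2-yl in place of phenyl on a double-bonded chain carbon bound to a double-bonded ring carbon. The measured step closest to this change is the one in which another five-membered aromatic ring with one hetero atom enters at the same place: no change at the digits printed from compound 1 to compound 2 (within the scatter). The remaining step, a 1.2-fold lower number from compound 2 to compound 3 (0.09 log units; within the scatter), also stays within the scatter, as does a 1.2-fold lower number from compound 1 to compound 3 (0.09 log units; within the scatter). Among the measured compounds shown here, nothing measured so far moves the number beyond the scatter, so for compound 4 in this assay no change beyond the scatter is expected, no change at the digits printed from compound 1 to compound 4 (within the scatter). Compound 4 is therefore estimated at 88000 nM, with a range from 40000 nM to 190000 nM.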

Compound 4, half-maximal inhibitory concentration: 94000 nM
The estimate for compound 4 lay 1.1-fold (0.03 log units) below the measured number, within the range that was stated.
By their numbers in this assay, from the lowest: compounds 3, 1, 2 and 4 (each within the scatter of the next).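

At the double-bonded chain carbon bound to a double-bonded ring carbon, furan-2-yl for phenyl in this assay gives a 1.1-fold higher number from compound 1 to compound 4 (0.03 log units; within the scatter) and furan-2-yl for thiophen-2-yl gives a 1.1-fold higher number from compound 2 to compound 4 (0.03 log units; within the scatter) while furan-2-yl for 4-methylphenyl gives a 1.3-fold higher number from compound 3 to compound 4 (0.12 log units; within the scatter) so all four aromatic rings now tested at this place lie within the scatter of one another. The result adds an oxygen-containing ring with a hydrogen-bond acceptor to this set, and the number in this assay does not move beyond the scatter with that change. No evidence on the reason for this flat picture is available.

As far as these compounds go, whether an open alkyl chain or a phenyl ring bearing an amine at this same place would move the number beyond the scatter remains open. Also open, from the compounds shown here alone, is what happens in this assay when the carboxylic acid of the shared core gives way to an amide.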